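Shortening the Linker and Adding Methoxy on the Aryl Ring

The source may report more compounds than this note shows. Statements on the series, on what has been measured and on what is new or still open speak of the compounds shown alone.

Compound 1, `CN1CCC[C@@H]1Cn1nc(Cc2ccc(C(C)(C)C)cc2)c2ccccc2c1=O`: in an assay for binding affinity to Alpha-1B adrenergic receptor (Homo sapiens) (on this read-out higher numbers stand for weaker inhibition and lower numbers for stronger inhibition), compound 1 reaches only the assay limit, > 1990 nM.
Compound 2, `CN1CCC[C@@H]1Cn1nc(CCc2ccccc2)c2ccccc2c1=O`: in this assay compound 2 gives 200 nM.

Going by the values given here, compound 2 holds the only numerical result in this set; the other entry is a limit, (the limit of > 1990 nM in this assay, at which 1 of the 2 values shown sits), so no measured step between the two can be stated beyond what the two values show. Compound 3, `COc1cccc(Cc2nn(C[C@H]3CCCN3C)c(=O)c3ccccc23)c1`, has not yet been measured. It differs from compound 2 by 3-methoxyphenyl in place of benzyl on a saturated chain carbon bound to an aromatic carbon, so the aryl ring is brought one carbon closer to the shared core and gains a methoxy group. Among the compounds with values here, with no measured step of comparable kind to lean on, a modest shift in this assay toward weaker binding is expected for compound 3, one the scatter may partly cover: the expected step is a 2.3-fold higher number from compound 2 to compound 3 (0.35 log units; beyond the scatter). Compound 3 is therefore estimated at 450 nM, with a range from 120 nM to 1990 nM.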

Compound 3, inhibition constant: > 1990 nM
Compound 3: only a limit was reported; the forecaster's own chance of this, stated with the estimate: 25%; middle value at least 4.4-fold (0.64 log units) away from the limit.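

Going by these compounds alone, replacing phenethyl with 3-methoxybenzyl gives an at least 9.9-fold higher number from compound 2 to compound 3 (0.99 log units; beyond the scatter) in this assay, the first step at this position that can be stated, and it shows that binding here is sensitive to this change. Going by these compounds, compound 3 reports only a limit, so the full size of the step remains unknown. Compound 3 and compound 1 cannot be ordered against each other, and no step between them can be read: the limit of > 1990 nM in this assay, at which 2 of the 3 values shown sit.

The compounds shown leave open whether the loss follows the shorter chain, the methoxy group or the two together, as compound 3 carries both changes at once. An unsubstituted benzyl group or a 3-methoxyphenethyl chain in the same place would separate the two.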